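From 4-methoxyphenyl to 4-chlorophenyl: working notes on the series

This account rests on a few compounds, and the source may have more. Where it says the series, first, only, none or still open, it means among the compounds named here.

Measured so far in a functional assay on DU-145 cells (Homo sapiens) for cytotoxicity, read by MTT assay, with a stated time of 48 h; a higher number here means a weaker inhibitor, a lower number a stronger inhibitor
- compound 1 `C=C1CCC[C@]2(C)CCC(c3cn(-c4ccc(OC)cc4)nn3)=CC[C@@]12C` gives 58900 nM
- compound 2 `C=C1CCC[C@]2(C)CCC(c3cn(CC(=O)Nc4ccc(C)cc4)nn3)=CC[C@@]12C` gives 254000 nM

Compound 1 holds the lower of these two numbers, and the number for compound 2 lies higher, beyond the scatter. The two compounds differ in more than one place, so their gap does not show the effect of any single change. Compound 3 `C=C1CCC[C@]2(C)CCC(c3cn(-c4ccc(Cl)cc4)nn3)=CC[C@@]12C` departs from compound 1 by one change chloro in place of methoxy on an aromatic carbon with chloro in place of methoxy on an aromatic carbon, para to a large group. Within the data shown here, no measured pair isolates this change, and no step beyond the scatter is expected in this assay from it. The expected step is a 1.3-fold lower number from compound 1 to compound 3 (0.12 log units; within the scatter) in the direction of a lower number, inside the scatter. Compound 3 is estimated at 45000 nM with a range from 20000 nM to 110000 nM in this measurement.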

Compound 3, half-maximal inhibitory concentration: 26000 nM
Estimate against measurement, compound 3: 1.7-fold (0.24 log units) above, within the range that was stated.
By their numbers in this assay, from the lowest: compound 3; then compound 1; then compound 2.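

Chloro in place of methoxy, on an aromatic carbon para to a large group, gives a 2.3-fold lower number from compound 1 to compound 3 (0.36 log units; beyond the scatter) in this assay. Among these compounds, this is the first single change that can be read, and it shows that the number responds to what sits at this place, though the step is modest and rests on one pair. Nothing at hand bears on why the number moves.

On these data alone, whether an amine, a carboxylic acid or a fluoro group at the same place would give a lower or a higher number remains open. Among the compounds shown here, it is also open whether chloro in place of methoxy would give a similar step on a different group at the triazole nitrogen, such as the one in compound 2.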